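The compounds below may be only part of what the source reports. "The series", "measured", "known", "first", "only" and "open" are said of these compounds alone.

In a functional assay on HepG2 cells (Homo sapiens) for cytotoxicity, read by MTT assay, with a stated time of 48 h (a higher number here means a weaker inhibitor, a lower number a stronger inhibitor), compound 3 (`O=c1cc(-c2ccccc2Cl)oc2c(CN3CCCCC3)cc(Cl)cc12`) gives 10700 nM, level with compound 2 (`CCN(CC)Cc1cc(Cl)cc2c(=O)cc(-c3ccccc3Cl)oc12`) at 7940 nM. Among the compounds with values here, the one measured step, a 1.3-fold higher number from compound 2 to compound 3 (0.13 log units; within the scatter), changes the group on the same saturated chain carbon and shows little movement. Compound 1 (`O=c1cc(-c2ccc([N+](=O)[O-])cc2)oc2c(Cn3ccnc3)cc(Cl)cc12`) already carries 1H-imidazol-1-yl at that place, differs elsewhere too, and gives a lower 2940 nM. Compound 4 (`O=c1cc(-c2ccccc2Cl)oc2c(Cn3ccnc3)cc(Cl)cc12`) replaces piperidin-1-yl of compound 3 with 1H-imidazol-1-yl: 1H-imidazol-1-yl in place of piperidin-1-yl on a saturated chain carbon bound to an aromatic carbon. Within the data shown here, no measured step covers this exact change, so the expectation rests on the small step above and, more loosely, on compound 1 at 2940 nM. The expected change in this assay is small, a 1.8-fold lower number from compound 3 to compound 4 (0.25 log units; within the scatter). Compound 4 is estimated at 6000 nM, with an expected range of 2500 nM to 14000 nM.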

Compound 4, half-maximal inhibitory concentration: 3270 nM
Estimate against measurement, compound 4: 1.8-fold (0.26 log units) above; the range from low to high includes it.
By their numbers in this assay, from the lowest: compounds 1 and 4 (each within the scatter of the next); then compounds 2 and 3 (each within the scatter of the next).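

In this assay the place on a saturated chain carbon bound to an aromatic carbon now shows a change beyond the scatter: 1H-imidazol-1-yl gives a 3.3-fold lower number from compound 3 to compound 4 (0.51 log units; beyond the scatter) and also a 2.4-fold lower number from compound 2 to compound 4 (0.39 log units; beyond the scatter) against diethylamino. The earlier swap between the two saturated amines had shown no such separation. With 1H-imidazol-1-yl held, the aryl swap gives a 1.1-fold higher number from compound 1 to compound 4 (0.05 log units; within the scatter) and so 2-chlorophenyl and 4-nitrophenyl read alike here.

From the compounds shown here alone, whether morpholin-4-yl or 1,2,4-triazol-1-yl at this place would follow piperidin-1-yl or 1H-imidazol-1-yl remains open. Nothing available explains the difference between these groups.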